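A few compounds are considered here, and "the series" means these few. Any claim that something is new, unique, unknown or untested is made for them only; others in the source may bear on it.

In a functional assay on MKN-45 cells (Homo sapiens) for inhibition, with a stated time of 72 h (a higher number here means a weaker inhibitor, a lower number a stronger inhibitor), compound 1 `COc1ccc(S(=O)(=O)N2CCc3cccc(-c4ccc(N)cc4)c32)cc1` gives 162 nM, compound 2 `COc1ccc(S(=O)(=O)N2CCc3cccc(-c4ccco4)c32)cc1` gives 42 nM and compound 3 `COc1ccc(S(=O)(=O)N2CCc3cccc(-c4cc(OC)c(OC)c(OC)c4)c32)cc1` gives 1080 nM. Compound 2 therefore has the lowest number of the three and is the strongest inhibitor among them, clear of the scatter against both others. Compound 4 `COc1ccc(S(=O)(=O)N2CCc3cccc(-c4ccncc4)c32)cc1` has yet to be measured. It carries pyridin-4-yl in place of furan-2-yl on an aromatic carbon of the shared core: pyridin-4-yl in place of furan-2-yl on an aromatic carbon. Going by the values given here, only one measured step touches this position with furan-2-yl as one partner: a 3.9-fold lower number from compound 1 to compound 2 (0.59 log units; beyond the scatter), a modest step beyond the scatter on replacing 4-aminophenyl. Among the compounds with values here, compound 3 also carries a six-membered aromatic ring at this place and has the highest number, though no single-place step links it to compound 2. Neither compound holds a ring nitrogen, so the guide is indirect. Within the data shown here, a modest move to a higher number is expected in this assay, of about the size of the one measured step. The expected step is a 2.6-fold higher number from compound 2 to compound 4 (0.42 log units; beyond the scatter). For compound 4 the estimated value is 110 nM, with an expected range of 30 nM to 400 nM.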

Compound 4, half-maximal inhibitory concentration: 69.5 nM
For compound 4 the middle estimate is 1.6-fold (0.20 log units) above the measured one; the range from low to high includes it.
By their numbers in this assay, from the lowest: compounds 2 and 4 (each within the scatter of the next); then compound 1; then compound 3.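

In this assay, putting pyridin-4-yl in place of furan-2-yl gives a 1.7-fold higher number from compound 2 to compound 4 (0.22 log units; within the scatter), so a six-membered aromatic ring on this aromatic carbon can match the five-membered one, which neither compound 1 nor compound 3 had shown. The six-membered rings here do not behave as one class: the same ring gives a 2.3-fold lower number from compound 1 to compound 4 (0.37 log units; beyond the scatter), and compound 3 stands at 1080 nM, so ring size alone does not set the number in this short series. Nothing measured here explains these differences.

On these data alone, what pyridin-3-yl or thiophen-2-yl would give at this place remains open, and with it whether the location of the ring hetero atom matters. Also open, as far as these compounds go, is whether a ring is needed here at all, a question that a simple amine or a short alkyl chain on this aromatic carbon would address.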